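The source may hold more compounds than are shown below. What is called first, only, known or untested is meant among the compounds shown, and "the series" means these compounds.

Compound 1 `Cn1cc(C(=O)Nc2ccc(-c3ccccc3)c(C(F)(F)F)c2)c(=O)c2ccccc21` is the starting point here, and it is measured in a physicochemical assay for solubility, in phosphate buffer, at pH 7.4; a higher number here means a more soluble compound, a lower number a less soluble compound. In this assay compound 1 gives < 1 ug/mL, which is a limit of the assay and not a number. Compound 2 `Cn1cc(C(=O)Nc2ccc(-c3ccccc3)c(C(F)(F)F)c2)c(=O)c2cccnc21` gives < 1 ug/mL, and this too is a limit. The record so far therefore consists of the limit of < 1 ug/mL in this assay, at which 2 of the 2 values shown sit. Among the compounds with values here, neither compound has a true number, so compound 1 stands at the floor of what is reported, and no measured step is available as a guide.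

Compound 3 `Cn1cc(C(=O)Nc2ccc(-c3ccccn3)c(C(F)(F)F)c2)c(=O)c2ccccc21` keeps the core of compound 1 and changes one group: pyridin-2-yl in place of phenyl on an aromatic carbon, ortho to a trifluoromethyl group and para to a large group (pyridin-2-yl in place of phenyl on an aromatic carbon). Within the data shown here, with no measured step to lean on, only a small upward move in this assay is expected, and a result that again stays at the limit would be no surprise. The expected step is small, an at least 1.5-fold higher number from compound 1 to compound 3 (0.17 log units; that floor lies within the scatter), and it carries wide uncertainty. For compound 3 the estimated value is 1.5 ug/mL, with an expected range from 0.5 ug/mL to 5 ug/mL.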

Compound 3, solubility: < 1 ug/mL
Compound 3: no number, only a limit; the forecaster's own chance of this, stated with the estimate: 50%; at least 1.5-fold (0.17 log units) between middle value and limit.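

Compound 1 and compound 3 both give only a limit in this assay, so no step can be read for pyridin-2-yl in place of phenyl, and the record stays as it was: the limit of < 1 ug/mL in this assay, at which 3 of the 3 values shown sit.

The compounds shown leave open what the true solubility of any of them is, and whether any change to this structure gives a readable number.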